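The source may hold more compounds than are shown below. What is called first, only, known or untested is meant among the compounds shown, and "the series" means these compounds.

- Compound 1 `COc1cc(/C=N/NC(=O)CCN2CCN(c3ccnc4cc(Cl)ccc34)CC2)ccc1O` gives 9400 nM
- Compound 2 `O=C(CCN1CCN(c2ccnc3cc(Cl)ccc23)CC1)N/N=C/c1ccc([N+](=O)[O-])cc1` gives 12100 nM

In an ADME assay on cells (Splenocyte, Mus musculus, strain BALB/c) for cytotoxicity, read by thymidine incorporation, with a stated time of 24 h (a higher number here means a weaker inhibitor, a lower number a stronger inhibitor), compound 2 stands at 12100 nM and lies within the scatter of compound 1 at 9400 nM so the two cannot be told apart. Compound 3 `O=C(CCN1CCN(c2ccnc3cc(Cl)ccc23)CC1)N/N=C/c1ccc(Cl)cc1` carries chloro in place of nitro on an aromatic carbon, para to a large group (chloro in place of nitro on an aromatic carbon). Going by the values given here, the one measured step bearing on this, also a change of the group on the carbon with a double bond to nitrogen, is a 1.3-fold higher number from compound 1 to compound 2 (0.11 log units; within the scatter) and so no step beyond the scatter is expected in this assay for this swap. Compound 3 is estimated at 10000 nM with an expected range of 4500 nM to 22000 nM. That estimate means an expected 1.2-fold lower number from compound 2 to compound 3 (0.08 log units; within the scatter).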

Compound 3, half-maximal inhibitory concentration: 200 nM
Compound 3: middle estimate off by 50-fold (1.70 log units), on the high side; the measured number lies below the stated range.
By their numbers in this assay, from the lowest: compound 3; then compounds 1 and 2 (each within the scatter of the next).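

The group on the carbon with a double bond to nitrogen can matter a great deal in this assay even though the earlier pair sat within the scatter of each other. Chloro in place of nitro on the aromatic carbon gives a large drop (a 61-fold lower number from compound 2 to compound 3 (1.78 log units; beyond the scatter)), and 4-chlorophenyl in place of 4-hydroxy-3-methoxyphenyl gives a similarly large one (a 47-fold lower number from compound 1 to compound 3 (1.67 log units; beyond the scatter)). Nothing available explains this sharp difference. Still open, on these data alone, is whether the drop is particular to chloro, or whether fluoro, bromo or methyl at the same place would behave alike.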